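The compounds below may be only part of what the source reports. "The series", "measured", "known", "first", "only" and "open" are said of these compounds alone.

Compounds measured so far in a functional assay on BGC-823 cells (Homo sapiens) for cytotoxicity, read by MTT assay; a lower number here means a stronger inhibitor, a higher number a weaker inhibitor:

- Compound 1 `COc1cc(/C=C/C(=O)c2sc(Nc3ccc(Cl)c(Cl)c3)nc2C)cc(OC)c1OC` gives a limit of > 25000 nM, not a number.
- Compound 2 `COc1cc(/C=C/C(=O)c2sc(Nc3cccc(C)c3)nc2C)cc(OC)c1OC` gives 17200 nM.
- Compound 3 `COc1cccc(/C=C/C(=O)c2sc(Nc3ccccc3C)nc2C)c1` gives a limit of > 25000 nM, not a number.

Among the measured compounds shown here, compound 2 therefore holds the only numeric value in this assay; the other two compounds sit at the limit, as summed up by the limit of > 25000 nM in this assay, at which 2 of the 3 values shown sit. Compound 4 `COc1cc(/C=C/C(=O)c2sc(Nc3cccc(Cl)c3)nc2C)cc(OC)c1OC` is not yet measured. It differs from compound 2 by chloro in place of methyl on an aromatic carbon; read one bond further out, this is 3-methylphenyl to 3-chlorophenyl.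

For the measured compounds named here, only one measured step changes a single place, an at least 1.4-fold lower number from compound 1 to compound 2 (0.16 log units; that floor lies within the scatter), and its size is only a floor that lies within the scatter. That step replaced 3,4-dichlorophenyl with 3-methylphenyl; the change to compound 4 puts a single chloro where the methyl stood. Going by the values given here, no measured pair reads exactly chloro in place of methyl, so the expectation rests on the step from compound 1 alone, and it points weakly toward a higher number, with a real chance that compound 4 again returns only a limit.

Compound 4 is estimated at 22000 nM, range 9000 nM to 55000 nM, a step of a 1.3-fold higher number from compound 2 to compound 4 (0.11 log units; within the scatter) that is expected to stay within the scatter.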

Compound 4, half-maximal inhibitory concentration: 11600 nM
Compound 4: the middle estimate sits 1.9-fold (0.28 log units) above what was measured; the range from low to high includes it.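

In this assay, chloro in place of methyl on this aromatic carbon is a 1.5-fold lower number from compound 2 to compound 4 (0.17 log units; within the scatter), so 3-methylphenyl and 3-chlorophenyl are not separated at this position, and the swap of one single substituent for the other has no readable effect here. Hydrogen in place of chloro on an aromatic carbon, which takes 3,4-dichlorophenyl to 3-chlorophenyl, is an at least 2.1-fold lower number from compound 1 to compound 4 (0.33 log units; beyond the scatter), the first step in the series to clear the scatter, and it places the second chloro of compound 1 as the change that counts, not the first. Compound 1 gives > 25000 nM, which is a limit and not a number, so this step is known only as a floor.

From the compounds shown here alone, whether a quite different group on this aromatic carbon, such as an amine, a carboxylic acid or a longer chain like propyl, would move the read-out beyond the scatter stays open. How far any change on this ring can be ranked also stays open, with much of the series giving no number: the limit of > 25000 nM in this assay, at which 2 of the 4 values shown sit.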